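Hydroxy to Trifluoromethyl: Expected Effect on Cell Tolerance

A few compounds are considered here, and "the series" means these few. Any claim that something is new, unique, unknown or untested is made for them only; others in the source may bear on it.

Measured compounds:
- Compound 1 `O=S(=O)(Nc1ccc(-c2nc3ccccc3o2)cc1)c1cccc(O)c1`: in an ADME assay on HEK293 cells (Homo sapiens) for cytotoxicity, read by resazurin assay, with a stated time of 48 h (a lower number here means that less compound is tolerated, a higher number that more compound is tolerated), compound 1 gives only a limit, > 100000 nM.
- Compound 2 `O=S(=O)(Nc1ccc(-c2nc3ccccc3o2)cc1)c1cccc(C(F)(F)F)c1`: in this assay compound 2 also gives only a limit, > 100000 nM.
- Compound 3 `O=S(=O)(Nc1ccc2oc(-c3ccccc3)nc2c1)c1ccccc1O`: in this assay compound 3 gives 33000 nM.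

Compound 1 and compound 2 differ by trifluoromethyl in place of hydroxy on an aromatic carbon. The step that the two limits leave unreadable from compound 1 to compound 2 cannot be sized, since the limit of > 100000 nM in this assay, at which 2 of the 3 values shown sit, holds both values. Compound 3 carries the same atoms as compound 1 joined differently; the difference between the two cores is not broken down here.

Compound 4 `O=S(=O)(Nc1ccc2oc(-c3ccccc3)nc2c1)c1ccccc1C(F)(F)F` is not yet measured. It differs from compound 3 by trifluoromethyl in place of hydroxy on an aromatic carbon. Among the measured compounds shown here, this is the same kind of change as the one from compound 1 to compound 2, though there the new group sits meta to a large group, here ortho to a large group.

With the earlier step unreadable, the expectation rests on compound 3 giving 33000 nM in this assay and on the change being small in kind. The expected step is a 1.2-fold higher number from compound 3 to compound 4 (0.08 log units; within the scatter). Compound 4 is therefore estimated at 40000 nM, between 12000 nM and 130000 nM.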

Compound 4, half-maximal cytotoxic concentration: 80000 nM
Beside the measured number, compound 4's estimate is 2.0-fold (0.30 log units) below it; measured number inside the range.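

In this assay, putting trifluoromethyl in place of hydroxy on the core of compound 3 gives a 2.4-fold higher number from compound 3 to compound 4 (0.38 log units; beyond the scatter), so on this core more compound is tolerated after the change, by a modest margin. The same change on the core of compound 1 cannot be read, so nothing here shows whether the step carries over from one core to the other, or even whether it has the same direction there: the limit of > 100000 nM in this assay, at which 2 of the 4 values shown sit. This leaves a single readable step, which describes compound 3 and compound 4 alone and sets no rule for the series.

The compounds shown leave open what other groups in the same place on this core, such as an amine, a carboxylic acid or a methyl group, would give. They also leave open how much of the step comes from losing hydroxy and how much from gaining trifluoromethyl, and what a plain hydrogen there would give.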